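Compound 4: Bromo in Place of Fluoro

A few compounds are considered here, and "the series" means these few. Any claim that something is new, unique, unknown or untested is made for them only; others in the source may bear on it.

Values in a functional assay on Caco-2 cells (Homo sapiens) for cytotoxicity, with a stated time of 48 h; on this read-out lower numbers stand for stronger inhibition and higher numbers for weaker inhibition:
Compound 1 `COc1cc(OC)c(C(=O)/C=C/c2ccccc2OC)c(OC)c1` gives 4500 nM
Compound 2 `COc1cccc(/C=C/C(=O)c2c(OC)cc(OC)cc2OC)c1` gives 3900 nM
Compound 3 `COc1cc(OC)c(C(=O)/C=C/c2ccc(F)cc2)c(OC)c1` gives 5500 nM

Compound 3 cannot be separated from the other two measured compounds, since its value lies within the scatter of both. The unmeasured compound 4 `COc1cc(OC)c(C(=O)/C=C/c2ccc(Br)cc2)c(OC)c1` differs from it in one place, with bromo in place of fluoro on an aromatic carbon. Within the data shown here, none of the measured steps puts bromo in place of fluoro, so the data hold no direct precedent.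

The nearest evidence comes from the three exchanges of the substituted phenyl group on the chain. These are a 1.2-fold lower number from compound 1 to compound 2 (0.06 log units; within the scatter), a 1.2-fold higher number from compound 1 to compound 3 (0.09 log units; within the scatter) and a 1.4-fold higher number from compound 2 to compound 3 (0.15 log units; within the scatter). All three are small in this assay, and none of the three compounds goes against that picture, though three compounds are a narrow basis. Given the two steps that involve compound 3, a change no larger than the scatter is expected for the new exchange, with no favoured direction. The estimated step is a 1.2-fold lower number from compound 3 to compound 4 (0.09 log units; within the scatter) as a central expectation. For compound 4 the estimated value is 4500 nM, with an expected range from 2200 nM to 9000 nM.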

Compound 4, half-maximal inhibitory concentration: 6800 nM
Compound 4: the middle estimate sits 1.5-fold (0.18 log units) below what was measured, and the stated range covers the measured number.
By their numbers in this assay, from the lowest: compounds 2, 1, 3 and 4 (each within the scatter of the next).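

In this assay, among these compounds, the first direct exchange of one halogen for another on this aromatic carbon, para to a large group, gives a 1.2-fold higher number from compound 3 to compound 4 (0.09 log units; within the scatter) and so leaves the read-out inside the scatter. Replacing the whole aryl group on the chain tells the same story: 4-bromophenyl in place of 3-methoxyphenyl gives a 1.7-fold higher number from compound 2 to compound 4 (0.24 log units; within the scatter) and 4-bromophenyl in place of 2-methoxyphenyl gives a 1.5-fold higher number from compound 1 to compound 4 (0.18 log units; within the scatter), which means that all four compounds remain inseparable on this read-out, and none goes against that picture. Nothing in the available data bears on what lies behind these small steps.

As far as these compounds go, all four compounds keep the shared core and carry only halogen or methoxy on the phenyl group, so it remains open whether an amine or a carboxylic acid on this same aromatic carbon would shift the number beyond the scatter. From the compounds shown here alone, it is equally open whether a longer chain between the carbonyl and the phenyl group would leave the read-out as flat as these exchanges have.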